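The source may hold more compounds than are shown below. What is called first, only, known or untested is meant among the compounds shown, and "the series" means these compounds.

Measured in a functional assay on DU-145 cells (Homo sapiens), read by sulforhodamine B assay, with a stated time of 5 days; a higher number here means a weaker inhibitor of growth, a lower number a stronger inhibitor of growth:
compound 1 `OC[C@H]1O[C@@H](n2cc(F)c3c(-c4ccccc4)ncnc32)[C@H](O)[C@@H]1O`: 580 nM
compound 2 `OC[C@H]1O[C@@H](n2cc(F)c3c(-c4nccs4)ncnc32)[C@H](O)[C@@H]1O`: 24 nM

Compound 2 holds the lower of the two numbers, 24 nM. The next change gives compound 3 `OC[C@H]1O[C@@H](n2cc(F)c3c(-c4ccsc4)ncnc32)[C@H](O)[C@@H]1O`, with thiophen-3-yl in place of 1,3-thiazol-2-yl on an aromatic carbon. Within the data shown here, only one measured step bears on it, a large one at the same place: a 24-fold lower number from compound 1 to compound 2 (1.38 log units; beyond the scatter), with 1,3-thiazol-2-yl in place of phenyl. Compound 3 keeps a five-membered aromatic ring, so only part of that gain is expected to be lost. The expected change in this assay is a modest rise, a 2.5-fold higher number from compound 2 to compound 3 (0.40 log units; beyond the scatter). The estimate for compound 3 is 60 nM, with an expected range of 15 nM to 250 nM.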

Compound 3, concentration for 50% growth inhibition: 66 nM
Compound 3: middle estimate off by 1.1-fold (0.04 log units), on the low side; measured number inside the range.
By their numbers in this assay, from the lowest: compound 2; then compound 3; then compound 1.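

In this assay, the advantage over phenyl at this position is not unique to 1,3-thiazol-2-yl: thiophen-3-yl also gives a lower number (an 8.8-fold lower number from compound 1 to compound 3 (0.94 log units; beyond the scatter)). Replacing 1,3-thiazol-2-yl with thiophen-3-yl gives back part of that advantage (a 2.8-fold higher number from compound 2 to compound 3 (0.44 log units; beyond the scatter)), so the two five-membered aromatic rings are not interchangeable here. Nothing available explains either step.

Open, from the compounds shown here alone, is whether thiophen-2-yl or furan-2-yl would follow compound 3 or compound 2. Also open, going by these compounds, is how a small amine or a methyl group would compare at this position.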